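Replacing Benzyloxy in Compound 1: An Expected Gain

The source may hold more compounds than are shown below. What is called first, only, known or untested is meant among the compounds shown, and "the series" means these compounds.

In a functional assay on CCRF-CEM cells (Homo sapiens) for inhibition, read by MTT assay, with a stated time of 72 h (on this read-out higher numbers stand for weaker inhibition and lower numbers for stronger inhibition), compound 1 (`COc1cc(NC(=O)/C=C/c2cccc(OCc3ccccc3)c2)cc(OC)c1OC`) gives 17300 nM as its reading. Compound 2 (`C=C(Br)C(=O)Nc1cccc(/C=C/C(=O)Nc2cccc(F)c2)c1`) gives 26000 nM and cannot be told apart from compound 1, since the gap lies within the scatter. Compound 3 (`C=C(Br)C(=O)Nc1cccc(/C=C/C(=O)Nc2ccc(Cl)cc2)c1`) gives 460 nM and stands well below both, which places compound 1 at the weak end of this small set.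

Compound 4 (`C=C(Br)C(=O)Nc1cccc(/C=C/C(=O)Nc2cc(OC)c(OC)c(OC)c2)c1`) departs from compound 1 by one exchange (((1-bromoethenyl)carbonyl)amino in place of benzyloxy on an aromatic carbon): ((1-bromoethenyl)carbonyl)amino in place of benzyloxy on an aromatic carbon, meta to a large group. Among the compounds with values here, no measured step isolates this exchange. Within the data shown here, the only measured step (a 57-fold lower number from compound 2 to compound 3 (1.75 log units; beyond the scatter)) is large and puts 4-chlorophenyl in place of 3-fluorophenyl on an amide-type nitrogen, with ((1-bromoethenyl)carbonyl)amino present on both sides. It bears on compound 4 only indirectly, showing that compounds carrying this group can sit at either end of the range, from compound 3 at 460 nM to compound 2 at 26000 nM. A moderate step beyond the scatter, toward stronger inhibition, is therefore expected in this assay with low confidence (an 8.7-fold lower number from compound 1 to compound 4 (0.94 log units; beyond the scatter)). The estimate for compound 4 is 2000 nM with 400 nM to 12000 nM as the expected range.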

Compound 4, half-maximal inhibitory concentration: 59 nM
Compound 4: the middle estimate sits 34-fold (1.53 log units) above what was measured, and the stated range ends above it.
By their numbers in this assay, from the lowest: compound 4; then compound 3; then compounds 1 and 2 (each within the scatter of the next).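

In this assay, ((1-bromoethenyl)carbonyl)amino in place of benzyloxy gives a large change (a 290-fold lower number from compound 1 to compound 4 (2.47 log units; beyond the scatter)), which shows that the group on this aromatic carbon, meta to a large group, can by itself shift the reading strongly with the rest of compound 1 unchanged. The earlier compounds shown here showed such a shift only for a change on the amide-type nitrogen (a 57-fold lower number from compound 2 to compound 3 (1.75 log units; beyond the scatter)), with ((1-bromoethenyl)carbonyl)amino present on both sides, so they left the contribution of this position untested. The exchange alters several things at once, removing a six-membered aromatic ring and adding a hydrogen-bond donor and two double bonds outside aromatic rings, and nothing available separates these features or accounts for the size of the step.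

From the compounds shown here alone, it remains open whether an amine or a simple acetylamino group on this carbon would read like benzyloxy or like ((1-bromoethenyl)carbonyl)amino, and a plain ethenylcarbonylamino group would be needed to isolate the part played by the bromine. Also open, going by these compounds, is whether the same exchange would give a step of similar size with the 4-chlorophenyl group of compound 3 on the amide-type nitrogen.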